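The compounds below may be only part of what the source reports. "The series", "measured", "known", "first", "only" and "open" are said of these compounds alone.

In a functional assay on PC-3 cells (Homo sapiens) for cytotoxicity, read by MTT assay, with a stated time of 72 h (on this read-out lower numbers stand for stronger inhibition and higher numbers for weaker inhibition), three compounds have numbers so far
compound 1 `CCN(CC)c1ccc(/C=N/NC(=O)Nc2cc3c(Nc4ccc(F)c(Cl)c4)ncnc3cc2O[C@H]2CCOC2)c(O)c1` gives 4590 nM
compound 2 `COc1ccc(/C=N/NC(=O)Nc2cc3c(Nc4ccc(F)c(Cl)c4)ncnc3cc2OC)cc1` gives 16500 nM
compound 3 `COc1cc2ncnc(Nc3ccc(F)c(Cl)c3)c2cc1NC(=O)N/N=C/c1cc(Br)c(O)c(Br)c1` gives 41500 nM

Compound 3 stands highest of the three, with compound 2 nearest to it and compound 1 furthest away. The next compound to be read is compound 4 `CCN(CC)c1ccc(/C=N/NC(=O)Nc2cc3c(Nc4ccc(F)c(Cl)c4)ncnc3cc2OC)c(O)c1`, which keeps everything in compound 3 except one group. The change is 4-(diethylamino)-2-hydroxyphenyl in place of 3,5-dibromo-4-hydroxyphenyl on a carbon with a double bond to nitrogen and puts 4-(diethylamino)-2-hydroxyphenyl in place of 3,5-dibromo-4-hydroxyphenyl on a carbon with a double bond to nitrogen. Among the measured compounds shown here, the only measured step at this place is a 2.5-fold higher number from compound 2 to compound 3 (0.40 log units; beyond the scatter), which is modest but beyond the scatter. It shows that this place can move the number, yet it does not involve the entering group. Compound 1 does carry that group, and its value (4590 nM) is well under that of compound 3 (41500 nM). For the measured compounds named here, compound 1 also differs from compound 3 elsewhere on the shared core, however, and no measured pair separates that second difference. A clear move to a lower number is therefore expected, larger than the measured step but less certain. The estimated step is a 5.5-fold lower number from compound 3 to compound 4 (0.74 log units; beyond the scatter) and it remains only an expectation. The estimated value for compound 4 is 7500 nM (expected range 2500 nM to 22000 nM).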

Compound 4, half-maximal inhibitory concentration: 34300 nM
The estimate for compound 4 lay 4.6-fold (0.66 log units) below the measured number; measured number above the stated range.
By their numbers in this assay, from the lowest: compound 1; then compound 2; then compounds 4 and 3 (each within the scatter of the next).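

In this assay, the step at the carbon with a double bond to nitrogen is a 1.2-fold lower number from compound 3 to compound 4 (0.08 log units; within the scatter), so with methyl on the oxygen on an aromatic ring, 4-(diethylamino)-2-hydroxyphenyl and 3,5-dibromo-4-hydroxyphenyl cannot be told apart, and both stand on the same side of 4-methoxyphenyl, as a 2.5-fold higher number from compound 2 to compound 3 (0.40 log units; beyond the scatter) and a 2.1-fold higher number from compound 2 to compound 4 (0.32 log units; beyond the scatter) show. The pair that differs only on that oxygen gives a 7.5-fold higher number from compound 1 to compound 4 (0.87 log units; beyond the scatter), with methyl in place of oxolan-3-yl, which ties the lower number of compound 1 to the oxolan-3-yl group and not to the 4-(diethylamino)-2-hydroxyphenyl group it shares with compound 4. Nothing among the data shown offers an explanation for any of these steps.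

From the compounds shown here alone, this oxolan-3-yl step is known only with 4-(diethylamino)-2-hydroxyphenyl in place, so whether it holds with 3,5-dibromo-4-hydroxyphenyl or 4-methoxyphenyl stays open. Also open, going by these compounds, is how other groups on that oxygen would read in this assay, such as a longer ether chain or a chain ending in an amine.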